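This account rests on a few compounds, and the source may have more. Where it says the series, first, only, none or still open, it means among the compounds named here.

Three close relatives of one shared core have been tested in a functional assay on CAKI-1 cells (Homo sapiens) for cytotoxicity, read by sulforhodamine B assay, with a stated time of 48 h; a lower number here means a stronger inhibitor of growth, a higher number a weaker inhibitor of growth. Compound 1 `ClCc1cccc(Cn2cnc3ncnc(Cl)c32)c1` carries one chloro group on the core and gives 2130 nM. Compound 3 `ClCc1ccccc1Cn1cnc2ncnc(Cl)c21` differs only in where the chloromethyl group sits on its pendant ring, and compound 3 gives 2340 nM. Compound 2 `ClCc1ccc(Cn2cnc3nc(Cl)nc(Cl)c32)cc1` carries two chloro groups on the core, and compound 2 gives 1440 nM. Compound 1 stands second highest of these three numbers; its nearest neighbour is compound 3, and the gap between the two is within the usual scatter, as is the somewhat larger gap to compound 2.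

Compound 4 `ClCc1cccc(Cn2cnc3nc(Cl)nc(Cl)c32)c1` is the next member: it differs from compound 1 by chloro in place of hydrogen on an aromatic carbon. Compound 2 shows that a second chloro group on this core, paired with a different pendant ring, yields a number within the scatter of compound 1. So the step from compound 1 to compound 4 is expected to be small, if anything a slight move toward a lower number, a 1.3-fold lower number from compound 1 to compound 4 (0.12 log units; within the scatter). On that basis compound 4 is expected to give about 1600 nM in this assay, within a range from 700 nM to 3500 nM.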

Compound 4, concentration for 50% growth inhibition: 1860 nM
For compound 4 the middle estimate is 1.2-fold (0.07 log units) below the measured one; low and high end bracket the measured number.
By their numbers in this assay, from the lowest: compounds 2, 4, 1 and 3 (each within the scatter of the next).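

Among these compounds, until now, a second chloro group on the shared core had been seen only in compound 2, paired with a different pendant ring, so its own contribution could not be separated from that of the ring. With the pendant ring held the same, placing chloro in place of hydrogen on the aromatic carbon between two ring nitrogen atoms gives a 1.1-fold lower number from compound 1 to compound 4 (0.06 log units; within the scatter) in this assay, so this single change leaves compound 1 and compound 4 indistinguishable in this measurement. No supporting measurement bears on why this position shows so little response to the change.

From the compounds shown here alone, it remains open whether the same calm holds for groups of a different kind at this position, such as an amine, a methoxy group or a longer carbon chain, any of which could show whether this carbon can carry a step beyond the scatter. Going by these compounds, it also remains open whether chloro in place of hydrogen here would read the same way when the chloromethyl group sits elsewhere on the pendant ring.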